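Aniline nitrogen methylation across two ester variants

This account rests on a few compounds, and the source may have more. Where it says the series, first, only, none or still open, it means among the compounds named here.

Compound 1 `CCOC(=O)CC1C(C(=O)OCC)=C(N)Oc2ccc(-c3cccc(N)c3)cc21` carries a free amine and ethyl esters; in a functional assay on HL-60 cells (Homo sapiens) for cytotoxicity, read by CellTiter-Blue, with a stated time of 48 h (on this read-out higher numbers stand for weaker inhibition and lower numbers for stronger inhibition), compound 1 gives 20200 nM. Compound 2 `CCOC(=O)CC1C(C(=O)OCC)=C(N)Oc2ccc(-c3cccc(NC)c3)cc21` adds (methyl in place of hydrogen on a nitrogen on an aromatic ring), and in this assay compound 2 gives 7450 nM, a step of a 2.7-fold lower number from compound 1 to compound 2 (0.43 log units; beyond the scatter). Compound 3 `C#CCOC(=O)CC1C(C(=O)OCC#C)=C(N)Oc2ccc(-c3cccc(NC)c3)cc21` carries propargyl esters; how the core of compound 3 differs from the core of compound 1 is not broken down here. In this assay compound 3 gives 880 nM, the lowest of the three numbers.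

Compound 4 `C#CCOC(=O)CC1C(C(=O)OCC#C)=C(N)Oc2ccc(-c3cccc(N(C)C)c3)cc21` differs from compound 3 by methyl in place of hydrogen on a nitrogen on an aromatic ring. This is the same kind of change as in the earlier pair, not the same: there the nitrogen's other neighbour was aromatic carbon only, here aromatic carbon and saturated chain carbon. Among the measured compounds shown here, for compound 4 the expected step is a 1.4-fold lower number from compound 3 to compound 4 (0.13 log units; within the scatter), smaller and less certain than the earlier one because a 2.7-fold lower number from compound 1 to compound 2 (0.43 log units; beyond the scatter) is the single measured precedent and sits at a differently substituted nitrogen. Compound 4 is estimated at 650 nM.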

Compound 4, half-maximal inhibitory concentration: 12000 nM
The estimate for compound 4 lay 18-fold (1.27 log units) below the measured number, and the stated range ends below it.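

The step to dimethylamino, a 14-fold higher number from compound 3 to compound 4 (1.13 log units; beyond the scatter), is in the opposite direction to the earlier methyl step in this assay. The effect of this change therefore does not carry from one core to the other in this series: the same change on two cores in this assay, a 2.7-fold lower number (0.43 log units; beyond the scatter) from compound 1 to compound 2 and a 14-fold higher number (1.13 log units; beyond the scatter) from compound 3 to compound 4, 37-fold (1.57 log units) apart, beyond the scatter of two such steps. This does not show what separates the two steps, since the pairs differ both in their esters (ethyl or propargyl) and in the nitrogen changed (free amine to methylamino, or methylamino to dimethylamino), and two pairs give no rule for other cores.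

As far as these compounds go, whether the reversal follows the propargyl esters or the second methyl stays open; a free amine with propargyl esters and a dimethylamino group with ethyl esters would separate the two. Also open, from the compounds shown here alone, is how a longer chain on the nitrogen, such as propyl, would read in this assay.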